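A few compounds are considered here, and "the series" means these few. Any claim that something is new, unique, unknown or untested is made for them only; others in the source may bear on it.

Working notes on the series. In an ADME assay on MT4 cells (Homo sapiens) for cytotoxicity, read by MTT assay, with a stated time of 96 h (a lower number here means that less compound is tolerated, a higher number that more compound is tolerated), compound 1 `Cc1ccccc1C1CC(c2ccc(OCc3ccccc3)cc2)=NN1c1ccc(S(N)(=O)=O)cc1` gives only a limit of the assay, >= 100000 nM. For the measured compounds named here, compound 2 `NS(=O)(=O)c1ccc(N2N=C(c3ccc(OCc4ccccc4)cc3)CC2c2ccccc2F)cc1` gives 39000 nM, the only true number so far, so it cannot yet be ranked against a measured spread. The next change leads to compound 3 `NS(=O)(=O)c1ccc(N2N=C(c3ccc(OCc4ccccc4)cc3)CC2c2cccc(Cl)c2)cc1`, with 3-chlorophenyl in place of 2-fluorophenyl on a saturated ring carbon. One measured step exists, an at least 2.5-fold lower number from compound 1 to compound 2 (0.40 log units; beyond the scatter), which is at least modest but open-ended and concerns fluoro in place of methyl on an aromatic carbon. It is a different exchange and gives only weak guidance. No clear direction is therefore expected in this assay, and the estimated 1.0-fold higher number from compound 2 to compound 3 (0.01 log units; within the scatter) stays within the scatter. For compound 3 the expected value is 40000 nM, with an estimated range of 15000 nM to 100000 nM.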

Compound 3, half-maximal cytotoxic concentration: 36000 nM
The estimate for compound 3 lay 1.1-fold (0.05 log units) above the measured number; the measured number falls inside the stated range.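

In this assay, 3-chlorophenyl in place of 2-fluorophenyl on the saturated ring carbon gives a 1.1-fold lower number from compound 2 to compound 3 (0.03 log units; within the scatter), so these two groups are not told apart here, although they differ in both the halogen and its place on the phenyl ring. Against 2-methylphenyl, the exchange gives an at least 2.7-fold lower number from compound 1 to compound 3 (0.44 log units; beyond the scatter), a second step beyond the scatter alongside an at least 2.5-fold lower number from compound 1 to compound 2 (0.40 log units; beyond the scatter), which leaves compound 1 alone apart from the other two. The true size of both steps stays open because compound 1 gives only a limit of the assay: the limit of >= 100000 nM in this assay, at which 1 of the 3 values shown sits.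

Whether the gap to compound 1 belongs to the methyl group itself or to its place on the phenyl ring remains unresolved with these three compounds. Also open, going by these compounds, is whether an amine or a carboxylic acid on this phenyl ring would shift the number beyond the scatter.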